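The compounds below may be only part of what the source reports. "The series", "measured", "known", "first", "only" and "open" are said of these compounds alone.

Measured in a functional assay on MCF7 cells (Homo sapiens) for inhibition, read by MTT assay, with a stated time of 48 h; a lower number here means a stronger inhibitor, a higher number a weaker inhibitor:
- compound 1 `COc1ccc(C(=O)C=CNc2cc(-c3ccccc3)nn2-c2ccccc2)cc1`: 1290 nM
- compound 2 `O=C(C=CNc1cc(-c2ccccc2)nn1-c1ccccc1)c1ccccc1`: 9650 nM

Compound 2 stands highest of the two, making it the weaker inhibitor here. The next change gives compound 3 `O=C(C=CNc1cc(-c2ccccc2)nn1-c1ccccc1)c1ccc(F)cc1`: fluoro in place of hydrogen on an aromatic carbon, para to a large group.

Among the compounds with values here, only one measured step bears on this: hydrogen in place of methoxy on an aromatic carbon, a 7.5-fold higher number from compound 1 to compound 2 (0.87 log units; beyond the scatter), modest but beyond the scatter. Within the data shown here, it concerns a different group, and no fluoro compound has been measured, so it gives only a loose guide. A smaller step towards a lower number is expected in this assay, possibly one that stays within the scatter. The expected change is a 1.8-fold lower number from compound 2 to compound 3 (0.24 log units; within the scatter). For compound 3 the estimated value is 5500 nM, with an expected range of 1800 nM to 14000 nM.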

Compound 3, half-maximal inhibitory concentration: 9180 nM
Compound 3: middle estimate off by 1.7-fold (0.22 log units), on the low side; the measured number falls inside the stated range.
By their numbers in this assay, from the lowest: compound 1; then compounds 3 and 2 (each within the scatter of the next).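

On the benzoyl ring, para to a large group, fluoro in place of hydrogen gives a 1.1-fold lower number from compound 2 to compound 3 (0.02 log units; within the scatter) in this assay, so this replacement leaves the number within the scatter. Of the three groups now seen at this place, only methoxy stands apart, with a 7.1-fold higher number from compound 1 to compound 3 (0.85 log units; beyond the scatter) in this assay, a step of about the same size as a 7.5-fold higher number from compound 1 to compound 2 (0.87 log units; beyond the scatter) and one showing that a para substituent here does not in itself bring the number down. No available evidence accounts for the difference between methoxy and fluoro.

As far as these compounds go, whether a hydroxy, ethoxy or dimethylamino group at this place would track compound 1 or compound 3 stays open. Also open, from the compounds shown here alone, is whether methoxy would give a similar step on another carbon of this ring.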